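Adding diethoxymethyl to compound 1

The compounds below may be only part of what the source reports. "The series", "measured", "known", "first", "only" and "open" are said of these compounds alone.

In an ADME assay on HeLa cells (Homo sapiens) for cytotoxicity, read by resazurin assay, with a stated time of 2 days (a lower number here means a stronger inhibitor, a higher number a weaker inhibitor), compound 1 (`Cn1c([N+](=O)[O-])cnc1/C=C/c1ccccc1`) gives > 100000 nM as its reading, which is a limit of the assay and not a number. Compound 3 (`COc1cccc(/C=C/c2ncc([N+](=O)[O-])n2C)c1`) gives > 100000 nM as its reading, which is also a limit. Compound 2 (`Cn1c([N+](=O)[O-])cnc1/C=C/c1cccc(Br)c1`) gives 87100 nM as a measured number. The small set is thus marked by the limit of > 100000 nM in this assay, at which 2 of the 3 values shown sit, and compound 1 is one of the two compounds that sit there.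

The step to compound 4 (`CCOC(OCC)c1ccc(/C=C/c2ncc([N+](=O)[O-])n2C)cc1`) is diethoxymethyl in place of hydrogen on an aromatic carbon and places diethoxymethyl in place of hydrogen on an aromatic carbon, para to a large group. Two measured steps make a similar kind of replacement on an aromatic carbon. Bromo gave an at least 1.1-fold lower number from compound 1 to compound 2 (0.05 log units; that floor lies within the scatter) and methoxy gave a step that the two limits leave unreadable from compound 1 to compound 3 while the exchange between those two groups gave an at least 1.1-fold higher number from compound 2 to compound 3 (0.05 log units; that floor lies within the scatter) as the third step. Neither group is diethoxymethyl, so these steps offer only a loose guide.

Going by the values given here, with compound 2 at 87100 nM as the only number, no step beyond the scatter is expected for compound 4 in this assay. The reading of compound 4 may again be only a limit. The estimate amounts to an at least 1.0-fold lower number from compound 1 to compound 4 (0.02 log units; that floor lies within the scatter) as the expected step. For compound 4 the expected value is 95000 nM with 45000 nM to 180000 nM as its estimated range.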

Compound 4, half-maximal inhibitory concentration: 97700 nM
Compound 4: the middle estimate sits 1.0-fold (0.01 log units) below what was measured; measured number inside the range.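

In this assay, diethoxymethyl in place of hydrogen on an aromatic carbon, para to a large group, gives an at least 1.0-fold lower number from compound 1 to compound 4 (0.01 log units; that floor lies within the scatter). Going by these compounds alone, none of the earlier compounds carries a group at this position, so compound 4 gives the first reading for it, and the entering group, with 7 heavy atoms, no ring and 2 hydrogen-bond acceptors, is also larger than bromo or methoxy. Even so, the step shows no change beyond the scatter, and with compound 1 resting on a limit only a floor can be read, a limit that still marks the set: the limit of > 100000 nM in this assay, at which 2 of the 4 values shown sit.

What the compounds shown leave open is whether any group at this position can bring the number clearly below that limit, and a single entry cannot say whether an amine or a carboxylic acid there would read differently from diethoxymethyl. From the compounds shown here alone, it is also open which part of diethoxymethyl matters to the reading, a question that a methyl ether, a longer chain or an aldehyde at the same place would bear on.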